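The compounds below may be only part of what the source reports. "The series", "measured", "known", "first", "only" and "open" are said of these compounds alone.

Within the data shown here, compound 2 `CC(C)c1nc(C2CCCCC2)nc(-c2ccc(F)cc2)c1/C=C/[C@@H]1C[C@@H](O)CC(=O)O1` has the higher of the two numbers measured so far: in an assay on HepG2 cells for inhibition of 3-hydroxy-3-methylglutaryl-coenzyme A reductase (Homo sapiens) (a lower number here means a stronger inhibitor, a higher number a weaker inhibitor), compound 2 gives 26 nM. Among the measured compounds shown here, its only measured neighbour, compound 1 `CC(C)c1nc(-c2ccc(F)cc2)c(/C=C/[C@@H]2C[C@@H](O)CC(=O)O2)c(C(C)C)n1`, gives 4.8 nM, and the step of a 5.4-fold higher number from compound 1 to compound 2 (0.73 log units; beyond the scatter) lies beyond the scatter. Compound 3 `CC(C)c1nc(-c2ccccc2)nc(-c2ccc(F)cc2)c1/C=C/[C@@H]1C[C@@H](O)CC(=O)O1` is the next step from compound 2: phenyl in place of cyclohexyl on an aromatic carbon. For the measured compounds named here, only one measured step is available to judge this move, and it bears on it only in part, since it compared an isopropyl with a cyclohexyl group at the same place and showed that enlarging the group there weakened inhibition, as seen in a 5.4-fold higher number from compound 1 to compound 2 (0.73 log units; beyond the scatter). Going by the values given here, no measured pair shows what happens when an aromatic ring replaces a saturated one of the same size at this place. The shift from cyclohexyl to phenyl is therefore expected to give at most a small step in this assay, in either direction, and compound 3 is estimated at 20 nM with a range of 6 nM to 70 nM, an expected step of a 1.3-fold lower number from compound 2 to compound 3 (0.11 log units; within the scatter).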

Compound 3, half-maximal inhibitory concentration: 5 nM
The estimate for compound 3 lay 4.0-fold (0.60 log units) above the measured number, outside the stated range (below it).
By their numbers in this assay, from the lowest: compounds 1 and 3 (each within the scatter of the next); then compound 2.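

Swapping cyclohexyl for phenyl on the ring carbon between the two ring nitrogen atoms leaves the heavy-atom count unchanged, yet this assay registers a 5.2-fold lower number from compound 2 to compound 3 (0.72 log units; beyond the scatter), so the count of atoms in the group does not decide the result here, and whether the six-membered ring is aromatic or non-aromatic goes with a clear difference. The earlier step from isopropyl to cyclohexyl could be read as a penalty for a bigger group, but phenyl, also a bigger group than isopropyl, gives a 1.0-fold higher number from compound 1 to compound 3 (0.02 log units; within the scatter), which lies within the scatter, so compound 1 and compound 3 cannot be told apart in this assay and the bigger group in compound 3 carries no visible cost. The data at hand offer no measurement that explains why the two six-membered rings differ in this way.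

Going by these compounds, whether the phenyl ring tolerates added groups, such as a fluorine or a methoxy group, remains open. So does the effect of a pyridine ring or an amine at this place, since every group shown here is built of carbon alone.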